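Amide change from compound 1 to compound 4

The source may report more compounds than this note shows. Statements on the series, on what has been measured and on what is new or still open speak of the compounds shown alone.

Among the measured compounds shown here, compound 1 `CCN(CC)S(=O)(=O)c1ccc(S(=O)(=O)N2CCC[C@@H](C(=O)N(C)C(C)C)C2)cc1` gives 7700 nM in a functional assay on BXPC-3 cells (Homo sapiens) for inhibition, read by MTT assay, with a stated time of 7 days (a lower number here means a stronger inhibitor, a higher number a weaker inhibitor), the highest number of the three measured so far. Compound 2 `CCOC(=O)[C@@H]1C[C@H](O)CN(S(=O)(=O)c2ccc(S(=O)(=O)N(CC)CC)cc2)C1` gives 3300 nM and compound 3 `CCOC(=O)[C@@H]1CCCN(S(=O)(=O)c2ccc(S(=O)(=O)N(CC)C(C)C)cc2)C1` gives 1600 nM; both gaps to compound 1 lie beyond the scatter, and compound 3 stands furthest from it. From the compounds shown here alone, compound 4 `CCN1CC(NC(=O)[C@@H]2CCCN(S(=O)(=O)c3ccc(S(=O)(=O)N(CC)CC)cc3)C2)C1` remains untested. Relative to compound 1 the change is (1-ethylazetidin-3-yl)amino in place of isopropyl(methyl)amino on a carbonyl carbon. For the measured compounds named here, no measured pair carries this change, so the data give no direct guide to its effect, and the two lower numbers of compound 2 and compound 3 come with other differences as well. The expected step is a 1.5-fold lower number from compound 1 to compound 4 (0.19 log units; within the scatter), a modest lowering that hardly clears the scatter. Compound 4 is estimated at 5000 nM, within 1500 nM to 16000 nM.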

Compound 4, half-maximal inhibitory concentration: > 30000 nM
Compound 4 gave a limit, no number; the forecaster's own chance of this, stated with the estimate: 5%; at least 6.0-fold (0.77 log units) between middle value and limit.
By their numbers in this assay, from the lowest: compound 3; then compound 2; then compound 1. At a limit, above all of these: compound 4.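

In this assay, among the compounds shown here, (1-ethylazetidin-3-yl)amino in place of isopropyl(methyl)amino on a carbonyl carbon gives an at least 3.8-fold higher number from compound 1 to compound 4 (0.59 log units; beyond the scatter), the only single change read so far and one that shows this amide position does not tolerate every substituent. Compound 4 gives a limit, not a number: the limit of > 30000 nM in this assay, at which 1 of the 4 values shown sits.

The step therefore fixes a direction but no exact size. Still open, from the compounds shown here alone, is which part of the entering group goes with the step: the four-membered ring, the amide hydrogen or the ethyl. Also open, going by these compounds, is how a carboxylic acid or a dimethylamino amide on this carbonyl carbon would read.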